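Thiophene amide on the shared core: expected affinity

This account rests on a few compounds, and the source may have more. Where it says the series, first, only, none or still open, it means among the compounds named here.

Compound 3 `CN1CCC(c2c[nH]c3ccc(NC(=O)c4ccc([N+](=O)[O-])cc4)nc23)CC1` gives 340 nM in an assay for binding affinity to 5-hydroxytryptamine receptor 1D (Homo sapiens), read by radioligand binding (a lower number here means a stronger inhibitor, a higher number a weaker inhibitor), the lowest of the three numbers; compound 2 `Cc1cccc(C(=O)Nc2ccc3[nH]cc(C4CCN(C)CC4)c3n2)c1` gives 490 nM and compound 1 `CN1CCC(c2c[nH]c3ccc(NC(=O)c4cccc(F)c4)nc23)CC1` gives 690 nM. Compound 4 `CN1CCC(c2c[nH]c3ccc(NC(=O)c4cccs4)nc23)CC1` differs from compound 3 in one place: thiophen-2-yl in place of 4-nitrophenyl on a carbonyl carbon. Going by the values given here, the steps that bear on this change both swap the group on the carbonyl carbon: a 2.0-fold lower number from compound 1 to compound 3 (0.31 log units; beyond the scatter) and a 1.4-fold lower number from compound 2 to compound 3 (0.16 log units; within the scatter). The step of a 1.4-fold lower number from compound 1 to compound 2 (0.15 log units; within the scatter) changes only a substituent on that aromatic ring and is of the same small size. All changes of the amide aryl group moved the number only modestly, so a step of similar size is expected here, more likely toward a higher number, compound 3 standing lowest of the three; the expected step is a 1.5-fold higher number from compound 3 to compound 4 (0.17 log units; within the scatter). Compound 4 is therefore estimated at 500 nM, with a range from 200 nM to 1500 nM.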

Compound 4, inhibition constant: 650 nM
The estimate for compound 4 lay 1.3-fold (0.11 log units) below the measured number, within the range that was stated.
By their numbers in this assay, from the lowest: compounds 3, 2, 4 and 1 (each within the scatter of the next, the first and the last beyond it).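

At this carbonyl carbon, the five-membered thiophen-2-yl ring holds up as well as the six-membered aromatic rings of carbon only in this assay: each step to or from compound 4 lies within the scatter (a 1.9-fold higher number from compound 3 to compound 4 (0.28 log units; within the scatter); a 1.3-fold higher number from compound 2 to compound 4 (0.12 log units; within the scatter); a 1.1-fold lower number from compound 1 to compound 4 (0.03 log units; within the scatter)). Compound 4 thus stays within the scatter of both compound 1 and compound 3, although those two stand beyond the scatter of each other. Nothing measured here explains this result.

The compounds shown leave open whether the position needs an aromatic ring at all, since a cyclohexyl ring or a short alkyl chain on the carbonyl carbon is not among them. From the compounds shown here alone, how thiophen-3-yl or a pyridine ring would compare also remains open.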